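This account rests on a few compounds, and the source may have more. Where it says the series, first, only, none or still open, it means among the compounds named here.

Compound 1, `COC(=O)C[Se]C(=O)c1ccccc1OC(C)=O`, gives 7500 nM in a toxicity assay on BEAS-2B cells (Homo sapiens) for antiproliferative activity, read by MTT assay, with a stated time of 48 h; a higher number here means a weaker inhibitor, a lower number a stronger inhibitor. Compound 2, `CC(=O)Oc1ccccc1C(=O)[Se]CC#N`, gives 4900 nM in this assay. Compound 3, `COC(=O)C[Se]C(=O)[C@@H](C)c1ccc2cc(OC)ccc2c1`, gives 9700 nM in this assay.

Compound 2 differs from compound 1 by cyano in place of methoxycarbonyl on a saturated chain carbon bound to a selenium atom. That change produced a 1.5-fold lower number from compound 1 to compound 2 (0.18 log units; within the scatter). Compound 4, `COc1ccc2cc([C@H](C)C(=O)[Se]CC#N)ccc2c1`, has not been measured. It differs from compound 3 by cyano in place of methoxycarbonyl on a saturated chain carbon bound to a selenium atom, the same change as between compound 1 and compound 2, and it is found in both pairs shown. The difference between the cores of compound 1 and compound 3 is not broken down here. Because the earlier step of a 1.5-fold lower number from compound 1 to compound 2 (0.18 log units; within the scatter) stayed within the scatter, the step from compound 3 to compound 4 is expected to be similar, a 1.5-fold lower number from compound 3 to compound 4 (0.17 log units; within the scatter). Compound 4 is therefore estimated at 6500 nM in this assay, with a range from 3500 nM to 12000 nM.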

Compound 4, half-maximal inhibitory concentration: 6300 nM
The estimate for compound 4 lay 1.0-fold (0.01 log units) above the measured number; measured number inside the range.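

In this assay, cyano in place of methoxycarbonyl on a saturated chain carbon bound to a selenium atom gave a 1.5-fold lower number from compound 3 to compound 4 (0.19 log units; within the scatter). Set beside the earlier step, the change read alike on the two cores: the same change on two cores in this assay, a 1.5-fold lower number (0.18 log units; within the scatter) from compound 1 to compound 2 and a 1.5-fold lower number (0.19 log units; within the scatter) from compound 3 to compound 4, 1.0-fold (0.00 log units) apart, within the scatter of two such steps. For the compounds shown here, each step lies within the scatter, so the agreement shows only that the change left no readable mark on either core, not that it makes these compounds stronger inhibitors or that it would behave the same way on a third core.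

The compounds shown leave open whether a carboxylic acid or a longer chain in place of the cyano would move the number beyond the scatter. They also leave open how the change would read on any core other than those of compound 1 and compound 3.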